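Hydroxamate series: chloro to methyl on the aryl ring

A few compounds are considered here, and "the series" means these few. Any claim that something is new, unique, unknown or untested is made for them only; others in the source may bear on it.

Measured compounds:
compound 1 `Cc1ccccc1CN1CC=C(CCC(=O)NO)C1=O` 3330 nM
compound 2 `O=C(CCC1=CCN(CCCc2ccc(Cl)cc2)C1=O)NO` 3330 nM
compound 3 `Cc1ccc(CN2CC=C(CCC(=O)NO)C2=O)cc1` 3330 nM

In a functional assay on ACHN cells (Homo sapiens) for inhibition, read by sulforhodamine B assay (a higher number here means a weaker inhibitor of growth, a lower number a stronger inhibitor of growth), compound 1 gives 3330 nM, compound 2 gives 3330 nM and compound 3 gives 3330 nM. Compound 2 thus stands level with compounds 1 and 3 at the digits shown; its nearest neighbour is compound 1 and its furthest is compound 3, both within the scatter. The three compounds vary the group carried on the amide nitrogen of the shared core without any shift in growth inhibition.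

Compound 4 `Cc1ccc(CCCN2CC=C(CCC(=O)NO)C2=O)cc1` is not yet measured. It differs from compound 2 in one place: methyl in place of chloro on an aromatic carbon.

Within the data shown here, no step between measured compounds is available. Given that the three measured variants all sit together, the change from compound 2 to compound 4 is expected to give no step beyond the scatter, no change at the digits printed from compound 2 to compound 4 (within the scatter). Compound 4 is therefore estimated at 3330 nM, within 1500 nM to 7500 nM.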

Compound 4, concentration for 50% growth inhibition: 3330 nM
Compound 4: the middle estimate sits on the measured number at the digits printed, and the stated range covers the measured number.
By their numbers in this assay, from the lowest: compounds 1, 2, 3 and 4 (each within the scatter of the next).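

In this assay, among these compounds, methyl in place of chloro on the aromatic carbon para to a large group gives no change at the digits printed from compound 2 to compound 4 (within the scatter) as the first single-place step. Chloro and methyl therefore read alike at this position, which the earlier compounds, with no single-place step among them, could not show. Nothing available bears on why the two groups read alike.

Still open, as far as these compounds go, is whether an amine, a carboxylic acid or a methoxy group at this position would give a step beyond the scatter. From the compounds shown here alone, a longer chain to the aryl ring also remains untested here.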